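The source may hold more compounds than are shown below. What is called first, only, known or untested is meant among the compounds shown, and "the series" means these compounds.

Compound 1 `N#Cc1c(Nc2ccccc2)nc(SCc2nc3ccccc3[nH]2)nc1-c1ccccc1` gives 4.46 nM
Compound 2 `CNc1nc(SCc2nc3ccccc3[nH]2)nc(-c2ccccc2)c1C#N` gives 3.2 nM

In a functional assay on SF-268 cells (Homo sapiens) for cytotoxicity, read by MTT assay, with a stated time of 3 days (a higher number here means a weaker inhibitor, a lower number a stronger inhibitor), compound 2 at 3.2 nM stands within the scatter of compound 1. Compound 3 `N#Cc1c(Nc2nccs2)nc(SCc2nc3ccccc3[nH]2)nc1-c1ccccc1` carries 1,3-thiazol-2-yl in place of methyl on a nitrogen on an aromatic ring. Among the measured compounds shown here, the one measured step at that nitrogen, methyl in place of phenyl, is a 1.4-fold lower number from compound 1 to compound 2 (0.14 log units; within the scatter) and lies within the scatter. For the measured compounds named here, no compound with 1,3-thiazol-2-yl has been measured, so that step is the only guide, and no step beyond the scatter is expected in this assay for this change. Expected on this reasoning is a 1.3-fold higher number from compound 2 to compound 3 (0.10 log units; within the scatter) as the size of the step. Compound 3 is estimated at 4 nM (from 1.3 nM to 12 nM).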

Compound 3, half-maximal inhibitory concentration: 2.55 nM
The estimate for compound 3 lay 1.6-fold (0.20 log units) above the measured number; measured number inside the range.
By their numbers in this assay, from the lowest: compounds 3, 2 and 1 (each within the scatter of the next).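

In this assay, the nitrogen on an aromatic ring also accepts 1,3-thiazol-2-yl, a five-membered aromatic ring with 2 hetero atoms: the change shows a 1.3-fold lower number from compound 2 to compound 3 (0.10 log units; within the scatter) and a 1.7-fold lower number from compound 1 to compound 3 (0.24 log units; within the scatter). Methyl, phenyl and 1,3-thiazol-2-yl at this place therefore give numbers that cannot be told apart. No available evidence bears on this result.

Still open, going by these compounds, is whether a longer alkyl chain or a carboxylic acid on this nitrogen would give a step beyond the scatter. The compounds shown also say nothing about changes elsewhere on the shared core.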